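A few compounds are considered here, and "the series" means these few. Any claim that something is new, unique, unknown or untested is made for them only; others in the source may bear on it.

In a functional assay on HCC827 cells (Homo sapiens) for inhibition, read by fluorescence, with a stated time of 72 h (on this read-out higher numbers stand for weaker inhibition of growth and lower numbers for stronger inhibition of growth), compound 1 (`COc1ccc(Nc2nc(N[C@H]3CC[C@H](N)CC3)nc3c2ncn3CCC(C)C)c(OC)c1`) gives 32900 nM, compound 2 (`CC(C)CCn1cnc2c(Nc3ccc(Cl)cc3)nc(N[C@H]3CC[C@H](N)CC3)nc21`) gives 10200 nM and compound 3 (`CCCCn1cnc2c(NCc3cccc(Cl)c3)nc(N[C@H]3CC[C@H](N)CC3)nc21`) gives 10600 nM. Compound 3 thus lies within the usual scatter of compound 2, and both have lower numbers than compound 1. Compound 4 (`CC(C)CCn1cnc2c(NCc3cccc(Cl)c3)nc(N[C@H]3CC[C@H](N)CC3)nc21`) turns the butyl chain of compound 3 into isopentyl, with methyl in place of hydrogen on a saturated chain carbon bound to two saturated chain carbons. Among the measured compounds shown here, the only measured step, a 3.2-fold lower number from compound 1 to compound 2 (0.51 log units; beyond the scatter), was modest, but it concerns a different group and does not test this chain change. No step beyond the scatter is therefore expected in this assay. The expected result is a 1.1-fold lower number from compound 3 to compound 4 (0.03 log units; within the scatter). Compound 4 is estimated at 10000 nM, within an expected range of 4500 nM to 22000 nM.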

Compound 4, concentration for 50% growth inhibition: 16700 nM
Compound 4: the middle estimate sits 1.7-fold (0.22 log units) below what was measured; low and high end bracket the measured number.
By their numbers in this assay, from the lowest: compounds 2, 3, 4 and 1 (each within the scatter of the next, the first and the last beyond it).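

In this assay the butyl-to-isopentyl change on this saturated chain carbon stays within the usual scatter (a 1.6-fold higher number from compound 3 to compound 4 (0.20 log units; within the scatter)), so the added methyl gives no difference that can be told apart from repeat variation. With the isopentyl chain kept, changing the group on the nitrogen on an aromatic ring also stays within the scatter, both for 4-chlorophenyl (a 1.6-fold higher number from compound 2 to compound 4 (0.21 log units; within the scatter)) and for 2,4-dimethoxyphenyl (a 2.0-fold lower number from compound 1 to compound 4 (0.29 log units; within the scatter)).

On these data alone, whether an amine, a carboxylic acid or a longer chain at this position would go beyond the scatter remains open. No evidence is available to explain these small differences.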